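The source may report more compounds than this note shows. Statements on the series, on what has been measured and on what is new or still open speak of the compounds shown alone.

In a functional assay (muscle tissue) with Felis catus as the target (a higher number here means that more compound is needed for the effect, a lower number that less compound is needed), the measured compounds are:

Compound 1 `Cc1nc(O)c(C#N)c(NCc2ccccn2)n1`: 43000 nM
Compound 2 `Cc1nc(O)c(C#N)c(NCc2ccncc2)n1`: 4400 nM
Compound 3 `Cc1nc(O)c(C#N)c(NCc2ccco2)n1`: 10000 nM

Of the three numbers, the middle one belongs to compound 3 at 10000 nM. The gaps on either side of it are a 2.3-fold higher number from compound 2 to compound 3 (0.36 log units; beyond the scatter) and a 4.3-fold lower number from compound 1 to compound 3 (0.63 log units; beyond the scatter), and both lie beyond the scatter.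

The next compound is compound 4 `CCNc1nc(C)nc(O)c1C#N`, which carries methyl in place of furan-2-yl on a saturated chain carbon bound to a nitrogen on an aromatic ring.

All three measured steps bear on this place, but each only exchanges one aromatic ring for another. The largest of them, a 9.8-fold lower number from compound 1 to compound 2 (0.99 log units; beyond the scatter), is still modest. Among the compounds with values here, no measured compound lacks an aromatic ring here, so the data show no direct precedent and do not settle the direction. A modest step towards a higher number in this assay is nevertheless the expectation, a judgement that rests on all three measured compounds carrying such a ring at this place. The expected change is a 2.0-fold higher number from compound 3 to compound 4 (0.30 log units; within the scatter). For compound 4, the estimated value is 20000 nM, with an expected range from 5000 nM to 70000 nM.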

Compound 4, half-maximal effective concentration: 2600 nM
For compound 4 the middle estimate is 7.7-fold (0.89 log units) above the measured one; measured number below the stated range.
By their numbers in this assay, from the lowest: compounds 4 and 2 (each within the scatter of the next); then compound 3; then compound 1.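

In this assay, an aromatic ring proves unnecessary at this place, on a saturated chain carbon bound to a nitrogen on an aromatic ring: replacing the two ring groups with methyl gives a 3.8-fold lower number from compound 3 to compound 4 (0.59 log units; beyond the scatter) for furan-2-yl and a 17-fold lower number from compound 1 to compound 4 (1.22 log units; beyond the scatter) for pyridin-2-yl. Within the data shown here, replacing pyridin-4-yl with methyl gives a 1.7-fold lower number from compound 2 to compound 4 (0.23 log units; within the scatter), so the far smaller group cannot be told apart from the ring that performs best among the earlier compounds, while furan-2-yl and pyridin-2-yl both need more compound for the effect. No measurement at hand accounts for these differences.

The compounds shown do not establish whether the number would hold if methyl gave way to a longer chain such as propyl, to a branched group such as isopropyl, or to a bare hydrogen on that carbon. They also leave open whether a phenyl ring or a saturated cyclohexyl ring at this place would follow methyl and pyridin-4-yl or the two groups that need more compound.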